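A few compounds are considered here, and "the series" means these few. Any claim that something is new, unique, unknown or untested is made for them only; others in the source may bear on it.

Measured compounds:
compound 1 `CCOc1cc(/C=C/C(=O)c2ccncc2)cc(OCC)c1OCC`, in an assay on HEK293 cells for inhibition of cytochrome P450 1A1 (Homo sapiens), read by fluorescence, with stated times of 30 min and 60 min; a lower number here means a stronger inhibitor, a higher number a weaker inhibitor: 92 nM
compound 2 `CCOc1cc(/C=C/C(=O)c2ccncc2)cc(OC)c1OCC`, in this assay: 65 nM
compound 3 `COc1ccc(/C=C/C(=O)c2ccncc2)cc1`, in this assay: 6610 nM

Compound 2 carries the lowest number of the three in this assay. Compound 1 stands nearest to it, within the scatter, so no order between the two is claimed; compound 3 stands furthest, with a far higher number, well beyond the scatter, but it differs from compound 2 in several places at once, so its gap says nothing about any single change.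

Compound 4 `CCOc1cc(/C=C/C(=O)c2ccncc2)cc(OC)c1OC` differs from compound 2 by hydrogen in place of methyl on a saturated chain carbon bound to an oxygen on an aromatic ring. One measured step is of the same kind: a 1.4-fold lower number from compound 1 to compound 2 (0.15 log units; within the scatter), which lay within the scatter. Among the compounds with values here, no other measured step bears on this change. On that basis the step from compound 2 to compound 4 in this assay is expected to stay within the scatter, in no definite direction: the expected step is a 1.1-fold higher number from compound 2 to compound 4 (0.03 log units; within the scatter). Compound 4 is therefore estimated at 70 nM, with a range from 30 nM to 160 nM.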

Compound 4, half-maximal inhibitory concentration: 63 nM
Beside the measured number, compound 4's estimate is 1.1-fold (0.05 log units) above it; the measured number falls inside the stated range.
By their numbers in this assay, from the lowest: compounds 4, 2 and 1 (each within the scatter of the next); then compound 3.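

In this assay, ethoxy to methoxy at a second oxygen on the aromatic ring again stays within the scatter, with a 1.0-fold lower number from compound 2 to compound 4 (0.01 log units; within the scatter), and this step changes a different ethoxy group from the one changed in the earlier step. Within compounds 1, 2 and 4, the place on a saturated chain carbon bound to an oxygen on an aromatic ring therefore tolerates this shortening at two separate oxygens, with no definite direction at either. No available evidence accounts for this result.

Going by these compounds, whether a longer chain such as propoxy, or a hydroxyl or an amine, would hold the number at these places remains open. Also open, on these data alone, is which of the several differences separates compound 3, at 6610 nM, from the rest of the series.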